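A few compounds are considered here, and "the series" means these few. Any claim that something is new, unique, unknown or untested is made for them only; others in the source may bear on it.

Working notes on the series.

Compound 1 `CCCCN1CCc2nc(C#Cc3ccccc3)sc2C1` is the reference point here. Among the compounds with values here, in an assay on HEK293 cells for positive allosteric modulation of metabotropic glutamate receptor 5 (Homo sapiens), read by FLIPR, with a stated time of 1 h (a higher number here means that more compound is needed for the effect, a lower number that less compound is needed), compound 1 gives 110 nM, the only number reported in this assay so far. Compound 2 `Fc1cccc(C#Cc2nc3c(s2)CN(C2CCOC2)CC3)c1` returns no number in this assay but a limit, > 10000 nM. Within the data shown here, that limit is the one described by the limit of > 10000 nM in this assay, at which 1 of the 2 values shown sits, so of the two values shown, one is a measured number and one is a limit, and no step between measured compounds can be read from the pair.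

Compound 3 `CC(=O)N1CCc2nc(C#Cc3ccccc3)sc2C1` differs from compound 1 by acetyl in place of butyl on an amine nitrogen in a ring. Among the measured compounds shown here, no measured step covers a change of this kind, so the expectation rests on the change itself and on the standing of compound 1. Compound 3 is expected to need more compound than compound 1 in this assay, by a step of a 14-fold higher number from compound 1 to compound 3 (1.13 log units; beyond the scatter) that is estimated to lie beyond the usual scatter. Compound 3 is estimated at 1500 nM in this assay, with a range from 300 nM to 8000 nM, and a fair chance that only a limit is returned.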

Compound 3, half-maximal effective concentration: > 10000 nM
Compound 3: a limit, no number; the forecaster's own chance of this, stated with the estimate: 20%; middle value at least 6.6-fold (0.82 log units) away from the limit.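

Within the data shown here, the ring amine nitrogen is not indifferent to the group it carries: acetyl in place of butyl on this nitrogen gives an at least 90-fold higher number from compound 1 to compound 3 (1.95 log units; beyond the scatter) in this assay, the first step that can be read at all, and it lies beyond the scatter. The result for compound 3, > 10000 nM, is a limit and not a number. Of the groups shown on this nitrogen in the shared core, only the butyl of compound 1 gives a measured number, and limits now make up most of the series: the limit of > 10000 nM in this assay, at which 2 of the 3 values shown sit.

The compounds shown leave open whether the step follows the carbonyl that enters with acetyl or the change in the chain itself, since both differences arrive together in this one change. From the compounds shown here alone, a plain propyl chain or a longer chain such as pentyl on the same nitrogen would bear on that question, as would a benzyl group, and how far the butyl of compound 1 can be varied remains unknown.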